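The compounds below may be only part of what the source reports. "The series", "measured", "known", "first", "only" and "open" are said of these compounds alone.

Measured so far, in an ADME assay on HEK-293T cells (Homo sapiens) for cytotoxicity, read by MTT assay, with a stated time of 24 h; on this read-out higher numbers stand for lower toxicity in this test and lower numbers for higher toxicity in this test:
compound 2 `Cc1ccc(-c2nn(-c3ccccc3)cc2-c2nc3ccccc3n2C(=O)c2cccc(C)c2)cc1`: 195000 nM
compound 3 `Cc1cccc(C(=O)n2c(-c3cn(-c4ccccc4)nc3-c3ccc(F)cc3)nc3ccccc32)c1`: 148000 nM
compound 1 `Cc1ccc(C(=O)n2c(-c3cn(-c4ccccc4)nc3-c3ccc(F)cc3)nc3ccccc32)cn1`: 137000 nM

Compound 2 has the highest of the three numbers, yet its nearest neighbour compound 3 sits only a 1.3-fold lower number from compound 2 to compound 3 (0.12 log units; within the scatter) away, and compound 1 lies no further from it than that. The three compounds therefore do not separate in this assay.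

Compound 4 `Cc1ccc(-c2nn(-c3ccccc3)cc2-c2nc3ccccc3n2C(=O)c2ccc(C)nc2)cc1` differs from compound 2 in one place: 6-methylpyridin-3-yl in place of 3-methylphenyl on a carbonyl carbon. For the measured compounds named here, the only measured step that bears on this exchange is the same change run the other way, a 1.1-fold higher number from compound 1 to compound 3 (0.03 log units; within the scatter), which stayed within the scatter. No step beyond the scatter is therefore expected here either, and any drift would go towards a slightly lower number, as a step of a 1.1-fold lower number from compound 2 to compound 4 (0.03 log units; within the scatter).

Compound 4 is estimated at 180000 nM, with a range from 100000 nM to 320000 nM.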

Compound 4, half-maximal cytotoxic concentration: 145000 nM
Compound 4: middle estimate off by 1.2-fold (0.09 log units), on the high side, and the stated range covers the measured number.
By their numbers in this assay, from the lowest: compounds 1, 4, 3 and 2 (each within the scatter of the next).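

In this assay, 6-methylpyridin-3-yl in place of 3-methylphenyl on the carbonyl carbon gives a 1.3-fold lower number from compound 2 to compound 4 (0.13 log units; within the scatter), so this exchange now stays within the scatter on a second core as well: the same change on two cores in this assay, a 1.1-fold higher number (0.03 log units; within the scatter) from compound 1 to compound 3 and a 1.3-fold higher number (0.13 log units; within the scatter) from compound 4 to compound 2, 1.2-fold (0.10 log units) apart, within the scatter of two such steps

Methyl in place of fluoro on an aromatic carbon, now read with 6-methylpyridin-3-yl on the carbonyl carbon, gives a 1.1-fold higher number from compound 1 to compound 4 (0.02 log units; within the scatter), and this exchange also holds on both cores: the same change on two cores in this assay, a 1.3-fold lower number (0.12 log units; within the scatter) from compound 2 to compound 3 and a 1.1-fold lower number (0.02 log units; within the scatter) from compound 4 to compound 1, 1.2-fold (0.10 log units) apart, within the scatter of two such steps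

The two exchanges therefore show no dependence on each other across these four compounds.

Every group shown at these two places leaves the number within the scatter, so no step yet marks what this position can do in this assay. Open, as far as these compounds go, is whether an amine or a carboxylic acid on the carbonyl carbon, or a longer chain in place of the methyl, would give a step beyond the scatter.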